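A Dichlorophenyl Variant of a Weakly Active Imide

This account rests on a few compounds, and the source may have more. Where it says the series, first, only, none or still open, it means among the compounds named here.

Of the compounds shown here, three sharing one core have been tested in a functional assay on the whole organism (strain CD-1) with Mus musculus as the target, in the maximal electroshock model, with a stated time of 0.5 h; a lower number here means that less compound is needed, a higher number that more compound is needed for the effect. Compound 1 `CC1(c2ccccc2)CC(=O)N(CC(=O)N2CCN(c3ccc(Cl)cc3)CC2)C1=O` gives "not active" (no number reported), and compound 2 `COc1cccc(N2CCN(C(=O)CN3C(=O)CC(C)(c4ccccc4)C3=O)CC2)c1` likewise gives "not active" (no number reported) in this assay. Compound 3 `CC1(c2ccccc2)CC(=O)N(CC(=O)N2CCN(c3ccc(F)cc3)CC2)C1=O` stands alone with a number, giving 100 mg/kg in this assay. Compound 4 `CC1(c2ccccc2)CC(=O)N(CC(=O)N2CCN(c3ccc(Cl)c(Cl)c3)CC2)C1=O` has not been measured; it differs from compound 3 by 3,4-dichlorophenyl in place of 4-fluorophenyl on an amine nitrogen in a ring. Among the compounds with values here, no step between measured compounds is available, so the size of this change cannot be read from earlier pairs. The expected step is a 2.0-fold higher number from compound 3 to compound 4 (0.30 log units; within the scatter), leaning toward more compound being needed, because compound 1 gives "not active" (no number reported). Compound 4 is therefore expected to give 200 mg/kg in this assay, within a range of 100 mg/kg to 400 mg/kg.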

Compound 4, minimum effective dose: "not active" (no number reported)
Compound 4 has no reported number here; no gap can be computed for the estimate.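

Compound 4 gives "not active" (no number reported) in this assay, so no new step from compound 3 to compound 4 can be read, and nothing shown accounts for this result. The compounds shown leave open whether any other group at this place would need less compound than compound 3.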